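The source may report more compounds than this note shows. Statements on the series, on what has been measured and on what is new or still open speak of the compounds shown alone.

Measured so far, in a functional assay on MCF7 cells (Homo sapiens) for antiproliferative activity, read by sulforhodamine B assay, with a stated time of 72 h; on this read-out higher numbers stand for weaker inhibition and lower numbers for stronger inhibition:

Compound 1, `O=C(Cn1nc(-c2ccccc2)c2ccccc2c1=O)Nc1cccc(Cl)c1`: 74000 nM
Compound 2, `O=C(Cn1nc(-c2ccccc2)c2ccccc2c1=O)Nc1ccc(Cl)cc1`: 33000 nM
Compound 3, `O=C(Cn1nc(Cc2ccccc2)c2ccccc2c1=O)Nc1cccc(Cl)c1`: 10800 nM

All three share a common core; compound 3 differs from compound 1 in that core by benzyl in place of phenyl on an aromatic carbon. That change gave a 6.9-fold lower number from compound 1 to compound 3 (0.84 log units; beyond the scatter), the largest step seen here, and it leaves compound 3 with the lowest number of the three in this assay.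

Compound 2 differs from compound 1 by 4-chlorophenyl in place of 3-chlorophenyl on an amide-type nitrogen. This change gave a 2.2-fold lower number from compound 1 to compound 2 (0.35 log units; beyond the scatter).

Compound 4, `O=C(Cn1nc(Cc2ccccc2)c2ccccc2c1=O)Nc1ccc(Cl)cc1`, has not yet been measured in this assay. It differs from compound 3 by 4-chlorophenyl in place of 3-chlorophenyl on an amide-type nitrogen. This is the same change, at the same kind of position, as that from compound 1 to compound 2, and the two structures around the place of change are described in the same words. The difference between the two pairs lies in the core: in compound 3 and compound 4 the benzyl group stands where compound 1 and compound 2 carry a phenyl group.

Within the data shown here, on that basis the step from compound 3 to compound 4 is expected to be about as large as the one from compound 1 to compound 2. The expected step is a 2.2-fold lower number from compound 3 to compound 4 (0.34 log units; beyond the scatter), because the earlier step was a 2.2-fold lower number from compound 1 to compound 2 (0.35 log units; beyond the scatter). It rests on a single pair, so the expectation is loosely held. Compound 4 is therefore estimated at 4900 nM, with a likely range from 2000 nM to 12000 nM.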

Compound 4, half-maximal inhibitory concentration: 13000 nM
Beside the measured number, compound 4's estimate is 2.7-fold (0.42 log units) below it; the whole stated range lies below it.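

The step seen on the core of compound 1 did not carry over to the core of compound 3. In this assay, putting 4-chlorophenyl in place of 3-chlorophenyl now gives a 1.2-fold higher number from compound 3 to compound 4 (0.08 log units; within the scatter) and so leaves no readable difference on this core, a result that sets the two cores apart: the same change on two cores in this assay, a 2.2-fold lower number (0.35 log units; beyond the scatter) from compound 1 to compound 2 and a 1.2-fold higher number (0.08 log units; within the scatter) from compound 3 to compound 4, 2.7-fold (0.43 log units) apart, beyond the scatter of two such steps.

The benzyl in place of phenyl change does keep its direction, giving a 2.5-fold lower number from compound 2 to compound 4 (0.40 log units; beyond the scatter) on the 4-chlorophenyl compounds, but its size does not hold from one pair to the other: the same change on two cores in this assay, a 6.9-fold lower number (0.84 log units; beyond the scatter) from compound 1 to compound 3 and a 2.5-fold lower number (0.40 log units; beyond the scatter) from compound 2 to compound 4, 2.7-fold (0.43 log units) apart, beyond the scatter of two such steps. So in these four compounds the effect of a change at one place depends on what stands at the other place, yet two pairs cannot show why this happens or whether it extends to other groups in the series.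

On these data alone, it remains open whether a 4-fluorophenyl or 4-methoxyphenyl group on the amide-type nitrogen would also lose its step on the benzyl core. A longer chain such as 2-phenylethyl in place of benzyl on the aromatic carbon would show whether the lower numbers continue beyond compound 3 and compound 4.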